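A few compounds are considered here, and "the series" means these few. Any claim that something is new, unique, unknown or untested is made for them only; others in the source may bear on it.

In a functional assay on HeLa cells (Homo sapiens) for cytotoxicity, read by MTT assay, with a stated time of 72 h (on this read-out lower numbers stand for stronger inhibition and higher numbers for weaker inhibition), compound 1 `N/C(=N\NC(=S)N1CCCCCC1)c1ccccn1` gives 6000 nM, compound 2 `N/C(=N\NC(=S)N1CCOCC1)c1ccccn1` gives 7300 nM and compound 3 `N/C(=N\NC(=S)N1CCN(c2ccccn2)CC1)c1ccc(F)cn1` gives 2000 nM. Compound 2 holds the highest of these three numbers; its gap to compound 1 lies within the scatter, while compound 3 sits at a lower number, a gap beyond the scatter. Compound 4 `Cc1ccnc(/C(N)=N/NC(=S)N2CCOCC2)c1` differs from compound 2 by methyl in place of hydrogen on an aromatic carbon, a methyl in place of hydrogen on an aromatic carbon. Among the compounds with values here, no pair of measured compounds differing in one place tests an edit of this kind, so the data give no size for it. A small step is expected, with no shift beyond the scatter, and the expected step from compound 2 to compound 4 is a 1.2-fold lower number from compound 2 to compound 4 (0.09 log units; within the scatter). Compound 4 is thus estimated at 6000 nM, with a range from 2500 nM to 15000 nM.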

Compound 4, half-maximal inhibitory concentration: 38500 nM
Beside the measured number, compound 4's estimate is 6.4-fold (0.81 log units) below it; measured number outside the range, above it.
By their numbers in this assay, from the lowest: compound 3; then compounds 1 and 2 (each within the scatter of the next); then compound 4.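

In this assay, methyl in place of hydrogen on the aromatic carbon opposite the ring nitrogen is not a silent edit: the step is a 5.3-fold higher number from compound 2 to compound 4 (0.72 log units; beyond the scatter), which is beyond the scatter. Within the data shown here, this gives the first size for any change at this position, and it runs toward weaker inhibition with only one heavy atom added. No data at hand bear on the reason for this step. From the compounds shown here alone, whether an ethyl chain, a methoxy group or an amine at this carbon moves the number the same way remains open. So does whether the methyl step carries over to the core of compound 1.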